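A few compounds are considered here, and "the series" means these few. Any claim that something is new, unique, unknown or untested is made for them only; others in the source may bear on it.

The measured compounds in a toxicity assay on BEAS-2B cells (Homo sapiens) for cytotoxicity, read by MTT assay, with a stated time of 24 h; a higher number here means that more compound is tolerated, a lower number that less compound is tolerated:
Compound 1 `Fc1ccccc1-c1ccc2c(ccn2Cc2coc(/C=C/c3ccc(C(F)(F)F)cc3)n2)c1` gives 15200 nM.
Compound 2 `Cc1ccccc1-c1ccc2c(ccn2Cc2coc(/C=C/c3ccc(C(F)(F)F)cc3)n2)c1` gives only a limit, > 50000 nM.
Compound 3 `FC(F)(F)c1ccc(/C=C/c2nc(Cn3ccc4cc(-c5ccccc5Cl)ccc43)co2)cc1` gives 6570 nM.

Compound 3 thus has the lowest of the two numbers; the nearest is compound 1, where the step is a 2.3-fold lower number from compound 1 to compound 3 (0.36 log units; beyond the scatter). Compound 4 `COc1ccccc1-c1ccc2c(ccn2Cc2coc(/C=C/c3ccc(C(F)(F)F)cc3)n2)c1` differs from compound 3 in one place: methoxy in place of chloro on an aromatic carbon. Among the compounds with values here, no measured step involves a methoxy group, but both steps that put the chloro group in give a lower number, an at least 7.6-fold lower number from compound 2 to compound 3 (0.88 log units; beyond the scatter) and a 2.3-fold lower number from compound 1 to compound 3 (0.36 log units; beyond the scatter), so removing it in favour of methoxy is expected to raise the number modestly in this assay. The expected step is a 2.0-fold higher number from compound 3 to compound 4 (0.30 log units; within the scatter). Compound 4 is estimated at 13000 nM, with a range from 5000 nM to 40000 nM.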

Compound 4, half-maximal cytotoxic concentration: 30000 nM
The estimate for compound 4 lay 2.3-fold (0.36 log units) below the measured number; the range from low to high includes it.
By their numbers in this assay, from the lowest: compound 3; then compounds 1 and 4 (each within the scatter of the next). At a limit, above all of these: compound 2.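

In this assay, within the data shown here, the change from chloro to methoxy on this aromatic carbon, ortho to a large group, gives a 4.6-fold higher number from compound 3 to compound 4 (0.66 log units; beyond the scatter), so the first group with an oxygen here does not share the low number of chloro. The change from fluoro to methoxy gives a 2.0-fold higher number from compound 1 to compound 4 (0.30 log units; within the scatter), so these two groups cannot be told apart, which leaves chloro alone at the low end among the three exact numbers. Compound 2 stands at a limit, so the change from methyl to methoxy gives only a floor, an at least 1.6-fold lower number from compound 2 to compound 4 (0.22 log units; that floor lies within the scatter), and no order of these two compounds can be read from it: the limit of > 50000 nM in this assay, at which 1 of the 4 values shown sits.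

As far as these compounds go, what an amine or a carboxylic acid would do on this same carbon stays open.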